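The compounds below may be only part of what the source reports. "The series", "measured", "known", "first", "only" and "open" are said of these compounds alone.

Compound 1 `CCCCN1CCc2nc(C#Cc3ccccc3)sc2C1` gives > 10000 nM in an assay on HEK293 cells for negative allosteric modulation of metabotropic glutamate receptor 5 (Homo sapiens), read by FLIPR, with a stated time of 1 h (on this read-out lower numbers stand for stronger inhibition and higher numbers for weaker inhibition), a limit of the assay.
Compound 2 `O=C(C1CC1)N1CCc2nc(C#Cc3ccccc3)sc2C1` gives 290 nM in this assay.
Compound 3 `COC1CC(C(=O)N2CCc3nc(C#Cc4ccccc4)sc3C2)C1` gives > 10000 nM in this assay, a limit of the assay.

Compound 3 thus stands at the limit, as does compound 1 (the limit of > 10000 nM in this assay, at which 2 of the 3 values shown sit); compound 2 alone yields a readable number. The step to compound 4 `O=C(C1CCOCC1)N1CCc2nc(C#Cc3ccccc3)sc2C1` is oxan-4-yl in place of 3-methoxycyclobutyl on a carbonyl carbon. Among the measured compounds shown here, two measured steps bear on it. an at least 34-fold higher number from compound 2 to compound 3 (1.53 log units; beyond the scatter) shows that replacing cyclopropyl by 3-methoxycyclobutyl on the carbonyl carbon carries the value from a number to the limit. an at least 34-fold lower number from compound 1 to compound 2 (1.53 log units; beyond the scatter) shows that the cyclopropylcarbonyl amide is where the one readable number sits. For the measured compounds named here, compound 4 keeps the amide and a small saturated ring, as compound 2 and compound 3 do, but no measured pair shows whether oxan-4-yl behaves like cyclopropyl or like 3-methoxycyclobutyl. The step is expected to be an at least 3.3-fold lower number from compound 3 to compound 4 (0.52 log units; beyond the scatter), a partial return toward a readable value. Compound 4 is therefore estimated at 3000 nM, between 600 nM and 15000 nM, with a real chance that only a limit is returned.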

Compound 4, half-maximal inhibitory concentration: > 10000 nM
Compound 4 gave a limit, no number; the forecaster's own chance of this, stated with the estimate: 40%; at least 3.3-fold (0.52 log units) between middle value and limit.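

In this assay compound 4 gives > 10000 nM, a limit of the assay. With an at least 34-fold higher number from compound 2 to compound 4 (1.53 log units; beyond the scatter), oxan-4-yl on the carbonyl carbon falls short of cyclopropyl just as 3-methoxycyclobutyl does, so the loss seen with compound 3 is not tied to the four-membered ring of carbon only or to one arrangement of these atoms. The steps from compound 3 to compound 4 and from compound 1 to compound 4 join two limits and cannot be read, and the values gather at one point: the limit of > 10000 nM in this assay, at which 3 of the 4 values shown sit.

The compounds shown do not separate the ring oxygen present in compound 3 and compound 4 from the larger ring itself. From the compounds shown here alone, whether plain cyclobutyl or cyclohexyl on the carbonyl carbon returns a readable number remains open.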